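This account rests on a few compounds, and the source may have more. Where it says the series, first, only, none or still open, it means among the compounds named here.

In an ADME assay on PC-3 cells (Homo sapiens) for cytotoxicity, read by WST assay, tested at 100 uM (on this read-out higher numbers stand for more inhibition at the one concentration tested (going by the name of the read-out) and lower numbers for less inhibition), the three measured compounds gave these values:

Compound 1 `O=C(Nc1cccc(N2CCCC2=O)c1)C1CCCN(C(=O)c2cc(C(F)(F)F)cc(C(F)(F)F)c2)C1`: 0%
Compound 2 `COC(=O)c1cccc(C(=O)N2CCCC(C(=O)Nc3ccc(Cl)cc3)C2)c1`: 0%
Compound 3 `CC(=O)c1cccc(NC(=O)C2CCCN(C(=O)c3cc(C(F)(F)F)cc(C(F)(F)F)c3)C2)c1`: 0%

All three compounds share a core, and none of them shows any inhibition in this assay. Compound 2 therefore stands level with compound 1 and compound 3 at the digits shown, and the gaps between them lie within the usual scatter of repeated measurements. Among the measured compounds shown here, the only step between two measured compounds that differ in a single place is no change at the digits printed from compound 1 to compound 3 (within the scatter): exchanging one group on an aromatic carbon left the read-out unchanged.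

Compound 4 `N#Cc1cccc(C(=O)N2CCCC(C(=O)Nc3ccc(Cl)cc3)C2)c1` is the compound not yet measured. It differs from compound 2 in one place: cyano in place of methoxycarbonyl on an aromatic carbon. For the measured compounds named here, no measured pair shows this particular exchange, so nothing in the data speaks directly to it. Going by the values given here, what the data do show is that every compound of this series so far, including one pair differing only at an aromatic carbon, sits at zero inhibition. Compound 4 is therefore expected to stay within the scatter of compound 2, so the expected step is no change at the digits printed from compound 2 to compound 4 (within the scatter). The estimate for compound 4 in this assay is 0%, with a range from 0% to 10%.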

Compound 4, a percentage reported as inhibition, at one concentration (the size of the read-out at that concentration, not a potency): 0%
Estimate against measurement, compound 4: no gap at the digits printed; the range from low to high includes it.
By their numbers in this assay, from the lowest: compounds 1, 2, 3 and 4 (each within the scatter of the next).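

In this assay, putting cyano in place of methoxycarbonyl on an aromatic carbon, meta to a large group, gives no change at the digits printed from compound 2 to compound 4 (within the scatter). Among the compounds shown here, the one earlier step changed different groups on a different pair of compounds, so this is the first direct look at this position and this exchange. It shows that a group of 2 heavy atoms with a triple bond can replace one of 4 heavy atoms with a double bond, and that one hydrogen-bond acceptor can stand where there were two, without any inhibition appearing at the one concentration tested; no measurement here offers an explanation for this outcome.

Since compound 2 and compound 4 both show no inhibition, this pair cannot show whether the exchange would matter in a compound that does inhibit in this read-out. From the compounds shown here alone, it also remains open whether a carboxylic acid, an amine or a longer alkyl chain on this same aromatic carbon would leave the read-out just as flat, or whether any of them would bring inhibition into view.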